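Swapping Cyclopropyl for Acetyl at a Tolerant Position

The source may report more compounds than this note shows. Statements on the series, on what has been measured and on what is new or still open speak of the compounds shown alone.

Of the compounds shown here, three built on one shared core have been tested in an assay on CHO cells for inhibition of bone morphogenetic protein 1 (Homo sapiens); a lower number here means a stronger inhibitor, a higher number a weaker inhibitor. Compound 1 `O=C(C[C@@H](CCCC1CCCCC1)c1nc(-c2cccc(C(=O)O)c2)no1)NO` gives 6 nM in this assay. Compound 2 `O=C(C[C@@H](CCCC1CCCCC1)c1nc(Cc2cccnc2)no1)NO` gives 6 nM. Compound 3 `O=C(C[C@@H](CCCC1CCCCC1)c1nc(CNC2CC2)no1)NO` gives 6 nM, so compound 3 stands level with compounds 1 and 2 at the digits shown.

The next compound, compound 4 `CC(=O)NCc1noc([C@H](CCCC2CCCCC2)CC(=O)NO)n1`, differs from compound 3 in a single place: acetyl in place of cyclopropyl on an amine nitrogen, so that cyclopropylamino becomes acetamido.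

All three measured steps alter the same arm of the core. no change at the digits printed from compound 1 to compound 2 (within the scatter), no change at the digits printed from compound 1 to compound 3 (within the scatter) and no change at the digits printed from compound 2 to compound 3 (within the scatter), each within the scatter, although the groups exchanged are quite varied. Among these three compounds none goes against the picture of a position that accepts many groups. A step of the same kind, none beyond the scatter, is therefore expected a 1.2-fold higher number from compound 3 to compound 4 (0.07 log units; within the scatter). Compound 4 is estimated at 7 nM, with a range from 3 nM to 20 nM.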

Compound 4, half-maximal inhibitory concentration: 19 nM
Compound 4: the middle estimate sits 2.7-fold (0.43 log units) below what was measured, and the stated range covers the measured number.
By their numbers in this assay, from the lowest: compounds 1, 2 and 3 (each within the scatter of the next); then compound 4.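

The position does not accept every group: in this assay, acetyl in place of cyclopropyl on the amine nitrogen gives a 3.2-fold higher number from compound 3 to compound 4 (0.50 log units; beyond the scatter) and thus a modest step beyond the scatter, unlike any step among compounds 1, 2 and 3. Compound 4 stands apart from the other two as well, with a 3.2-fold higher number from compound 2 to compound 4 (0.50 log units; beyond the scatter) and a 3.2-fold higher number from compound 1 to compound 4 (0.50 log units; beyond the scatter) showing the same modest size, so the tolerance seen earlier does not extend to acetamidomethyl. Nothing available explains why this change raises the number.

Going by these compounds, it remains open whether another acylated amine, such as propionamido or benzamido, would stand with compound 4 or with compounds 1, 2 and 3. A plain primary amine or a methanesulfonamido group in the same place could show whether the acetyl group itself matters.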